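Furan-2-yl for cyclohexyl on the amide of compound 2

The compounds below may be only part of what the source reports. "The series", "measured", "known", "first", "only" and "open" are said of these compounds alone.

Compound 1 `COc1ccccc1-c1cnc(NC(=O)c2ccc(F)cc2)n1C` is one of three amide-linked analogues on a shared core. In a toxicity assay on THP-1 cells (Homo sapiens) for inhibition (on this read-out lower numbers stand for higher toxicity in this test and higher numbers for lower toxicity in this test), compound 1 gives > 100000 nM, which is a limit of the assay and not a number. Compound 2 `COc1ccc(-c2cnc(NC(=O)C3CCCCC3)n2C)cc1` carries a cyclohexyl on the carbonyl carbon. In this assay compound 2 gives > 100000 nM, again a limit of the assay. Compound 3 `Cn1c(-c2ccccc2)cnc1NC(=O)c1ncc[nH]1` completes the measured set. In this assay compound 3 gives > 100000 nM, also a limit. Compound 2 therefore stands where every measured member stands, namely at the limit of > 100000 nM in this assay, at which 3 of the 3 values shown sit, so no ordering among the three can be read from these values. Within the data shown here, no step between measured compounds is available to calibrate the change.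

The change to compound 4 `COc1ccc(-c2cnc(NC(=O)c3ccco3)n2C)cc1` is furan-2-yl in place of cyclohexyl on a carbonyl carbon. With the whole series sitting at the limit, nothing in the data points to either direction. The step is expected to be a step that the limit leaves unreadable from compound 2 to compound 4, that is, none beyond the scatter. Compound 4 is estimated to give about 150000 nM in this assay, with a range from 50000 nM to 500000 nM, and most likely reported as a limit once more.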

Compound 4, half-maximal cytotoxic concentration: > 100000 nM
Compound 4: no number, only a limit (the forecaster's own chance of this, stated with the estimate: 80%); the middle value is on the limit's open side.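

Compound 2 and compound 4 give no readable step in this assay, and neither result is a number: the limit of > 100000 nM in this assay, at which 4 of the 4 values shown sit.

The compounds shown leave open how they rank against one another in this assay, and which change on the shared core, if any, would give a value inside the assay's range.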